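Adding a Second Chloro: What to Expect for Compound 4

This account rests on a few compounds, and the source may have more. Where it says the series, first, only, none or still open, it means among the compounds named here.

Compound 3 `CC(=O)OC/C(=C\c1ccc(Cl)cc1)C(=O)c1ccc(Cl)cc1` belongs to a small set of acetate esters built on a shared core. In a functional assay on HeLa cells (Homo sapiens) for inhibition, read by sulforhodamine B assay, with a stated time of 48 h (on this read-out higher numbers stand for weaker inhibition of growth and lower numbers for stronger inhibition of growth), compound 3 gives 19000 nM. Compound 1 `CC(=O)OC/C(=C\c1ccc(Cl)cc1Cl)C(=O)c1ccccc1` gives 16000 nM, and compound 2 `CC(=O)OC/C(=C\C1CCCCC1)C(=O)c1ccc(Cl)cc1` gives 24000 nM. Among these three numbers compound 3 sits second highest; compound 1 is nearest and compound 2 furthest, and both gaps fall within the scatter. For the measured compounds named here, the only step between two compounds that differ in a single place, a 1.3-fold lower number from compound 2 to compound 3 (0.10 log units; within the scatter), is likewise within the scatter. Compound 4 `CC(=O)OC/C(=C\c1ccc(Cl)cc1Cl)C(=O)c1ccc(Cl)cc1` differs from compound 3 by chloro in place of hydrogen on an aromatic carbon. Going by the values given here, no measured pair differs by this chloro alone, so the change has no direct precedent in this set. Compound 1 and compound 3, which are not a single-place pair, give numbers within the scatter of each other. With all three measured numbers sitting close together, the expected step is a 1.1-fold lower number from compound 3 to compound 4 (0.05 log units; within the scatter), nothing beyond the scatter. Compound 4 is therefore estimated at 17000 nM, with a likely range from 8000 nM to 36000 nM.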

Compound 4, concentration for 50% growth inhibition: 4600 nM
Compound 4: the middle estimate sits 3.7-fold (0.57 log units) above what was measured, outside the stated range (below it).
By their numbers in this assay, from the lowest: compound 4; then compounds 1, 3 and 2 (each within the scatter of the next).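

In this assay, for the compounds shown here, chloro in place of hydrogen on this aromatic carbon, ortho to a large group and meta to a chloro group, gives a 4.1-fold lower number from compound 3 to compound 4 (0.62 log units; beyond the scatter) and so brings a real gain in growth inhibition, which the earlier compounds, all close together, gave no sign of. The other ring matters as well: a chloro entering there gives a 3.5-fold lower number from compound 1 to compound 4 (0.54 log units; beyond the scatter), and 2,4-dichlorophenyl in place of cyclohexyl gives a 5.2-fold lower number from compound 2 to compound 4 (0.72 log units; beyond the scatter), while 4-chlorophenyl in that place gave only a 1.3-fold lower number from compound 2 to compound 3 (0.10 log units; within the scatter) within the scatter. Nothing shown here explains this gain.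

As far as these compounds go, whether the gain is particular to chloro stays open, since a methoxy group or a bromo group on this same carbon could behave differently. Also open, from the compounds shown here alone, is whether it would survive with a carboxylic acid or an amine in place of the acetate ester.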